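Aryl phosphate esters of an azido-thymidine core: stability

This account rests on a few compounds, and the source may have more. Where it says the series, first, only, none or still open, it means among the compounds named here.

Measured so far:
compound 1, `Cc1cn([C@H]2C[C@H](N=[N+]=[N-])[C@@H](COP(=O)(O)Oc3ccncc3)O2)c(=O)[nH]c1=O`: 8.07 h
compound 2, `Cc1cn([C@H]2C[C@H](N=[N+]=[N-])[C@@H](COP(=O)(O)Oc3ccccc3)O2)c(=O)[nH]c1=O`: 9.47 h

Of the compounds shown here, two sharing one core have been measured in a physicochemical assay for metabolic stability, read by HPLC; a lower number here means that the compound disappears faster, a higher number that the compound lasts longer. Compound 1, with a pyridin-4-yl group on the phosphate oxygen, gives 8.07 h. Compound 2, carrying a phenyl in the same place, gives 9.47 h, the higher of the two numbers, though the step of a 1.2-fold higher number from compound 1 to compound 2 (0.07 log units; within the scatter) lies within the usual scatter, so no order between the two can be claimed.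

Compound 3, `Cc1cn([C@H]2C[C@H](N=[N+]=[N-])[C@@H](COP(=O)(O)Oc3ccc(Cl)cc3Cl)O2)c(=O)[nH]c1=O`, has not yet been measured. It differs from compound 2 by 2,4-dichlorophenyl in place of phenyl on an oxygen. Among the measured compounds shown here, the only measured step that bears on this change is the exchange of one aryl group for another on that same oxygen, a 1.2-fold higher number from compound 1 to compound 2 (0.07 log units; within the scatter), which did not move the half-life beyond the scatter. With a single such comparison in hand, and none involving a chlorinated aryl group, the expected step for compound 3 is a 1.3-fold lower number from compound 2 to compound 3 (0.10 log units; within the scatter), essentially none beyond the scatter. Compound 3 is therefore estimated at 7.5 h, with a range from 3.5 h to 15 h.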

Compound 3, half-life: 3.03 h
For compound 3 the middle estimate is 2.5-fold (0.39 log units) above the measured one; measured number outside the range, below it.
By their numbers in this assay, from the lowest: compound 3; then compounds 1 and 2 (each within the scatter of the next).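

In this assay, the group on this oxygen turns out to be able to move the half-life: putting 2,4-dichlorophenyl in place of phenyl gives a 3.1-fold lower number from compound 2 to compound 3 (0.49 log units; beyond the scatter), and putting it in place of pyridin-4-yl gives a 2.7-fold lower number from compound 1 to compound 3 (0.43 log units; beyond the scatter). The earlier exchange of one aryl group for another on the same oxygen had stayed within the scatter, so compound 3 is the first compound here to stand clearly apart, with the shortest half-life of the three, and the 2,4-dichlorophenyl group is the only one shown that separates from the others. Nothing available accounts for this drop.

The 2,4-dichlorophenyl group brings in both chlorine atoms at once, so the compounds shown do not tell whether a phenyl carrying a single chlorine would give a step of this size, or whether both chlorine atoms are needed. They also leave open whether a methoxyphenyl group or a plain ethyl group on that oxygen would stay close to compound 1 and compound 2 or fall towards compound 3.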